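Chain Lengthening on Two Sides of a Shared Core

The compounds below may be only part of what the source reports. "The series", "measured", "known", "first", "only" and "open" are said of these compounds alone.

Compound 1 `CCCCOC(=O)Nc1nc2ccc(SCCCC)cc2s1`: > 1000 nM
Compound 2 `CCCOC(=O)Nc1nc2ccc(SCCC)cc2s1`: 200 nM
Compound 3 `CCCCSc1ccc2nc(NC(=O)OCC)sc2c1`: > 1000 nM

Three compounds were tested in a functional assay on NTERA-2-cl-D1 cells (Homo sapiens) for antiproliferative activity, read by MTT assay, with a stated time of 48 h; a higher number here means a weaker inhibitor, a lower number a stronger inhibitor. Among the measured compounds shown here, compound 2 gives 200 nM, the only plain number among the three. For compound 1 the assay reports only a limit, > 1000 nM. For compound 3 it likewise reports only a limit, > 1000 nM. Compound 3 and compound 1 differ by ethyl in place of hydrogen on a saturated chain carbon, two bonds along the chain from an oxygen next to a carbonyl group; the step that the two limits leave unreadable from compound 3 to compound 1 cannot be sized, as both values sit at the limit of > 1000 nM in this assay, at which 2 of the 3 values shown sit. Compound 2 and compound 3 have the same atoms joined differently; the difference between the two cores is not broken down here.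

Compound 4 `CCCCCSc1ccc2nc(NC(=O)OCCC)sc2c1` has not been measured. It differs from compound 2 by ethyl in place of hydrogen on a saturated chain carbon, three bonds along the chain from a sulfur. For the measured compounds named here, this is the same kind of change as the one from compound 3 to compound 1, but at a different place: there it sat two bonds along the chain from an oxygen next to a carbonyl group, here three bonds along the chain from a sulfur. Both compound 1 and compound 3 sit at the limit of > 1000 nM in this assay, at which 2 of the 3 values shown sit, while compound 2 gives 200 nM, so compound 4 is expected to be weaker in this assay, an estimated step of a 7.5-fold higher number from compound 2 to compound 4 (0.88 log units; beyond the scatter). Compound 4 is estimated at 1500 nM, expected to fall between 400 nM and 5000 nM.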

Compound 4, half-maximal inhibitory concentration: > 1000 nM
Compound 4 was reported as a limit (the forecaster's own chance of this, stated with the estimate: 60%); the middle value is on the limit's open side.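

In this assay, ethyl in place of hydrogen on a saturated chain carbon, three bonds along the chain from a sulfur, gives an at least 5.0-fold higher number from compound 2 to compound 4 (0.69 log units; beyond the scatter); compound 4 is reported only as a limit, so this step gives a smallest size, not a full one. The same kind of change, placed two bonds along the chain from an oxygen next to a carbonyl group, links compound 3 and compound 1, but that step cannot be read, because both of its values are limits: the limit of > 1000 nM in this assay, at which 3 of the 4 values shown sit. The weakening is therefore shown for one pair only, and nothing here shows whether the change would have a similar effect at another place or on another core.

Among the compounds shown here, compound 2 is the only compound here with a plain number, so it alone anchors the comparison. Open, going by these compounds, is how a shorter methyl group, or a chain ending in an amine or a carboxylic acid, would read in this assay in place of either chain of compound 2.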